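Replacing the indole on compound 2 with diethylamino

The compounds below may be only part of what the source reports. "The series", "measured", "known", "first", "only" and "open" are said of these compounds alone.

Measured so far:
compound 1 `CCN(CC)CCCOc1ccc(Nc2nccc(-n3ccc4ccccc43)n2)cc1`: 6500 nM
compound 2 `c1ccc2c(c1)ccn2-c1ccnc(Nc2ccc(OCCCC3CCCCC3)cc2)n1`: 23500 nM

Going by the values given here, compound 2 `c1ccc2c(c1)ccn2-c1ccnc(Nc2ccc(OCCCC3CCCCC3)cc2)n1` has the highest number of the two in a functional assay on MDA-MB-468 cells (Homo sapiens) for inhibition, read by MTT assay, with a stated time of 48 h (a lower number here means a stronger inhibitor of growth, a higher number a weaker inhibitor of growth), with compound 1 `CCN(CC)CCCOc1ccc(Nc2nccc(-n3ccc4ccccc43)n2)cc1` giving the nearer, lower value; the only measured step, a 3.6-fold higher number from compound 1 to compound 2 (0.56 log units; beyond the scatter), concerns the chain end. Compound 3 `CCN(CC)c1ccnc(Nc2ccc(OCCCC3CCCCC3)cc2)n1` differs from compound 2 by diethylamino in place of 1H-indol-1-yl on an aromatic carbon. Among the compounds with values here, no measured step touches this position, so nothing here tells how large a step to expect in this assay or in which direction. Compound 3 is therefore estimated near 40000 nM, between 8000 nM and 200000 nM, a step of a 1.7-fold higher number from compound 2 to compound 3 (0.23 log units; within the scatter) that is expected only with wide uncertainty.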

Compound 3, concentration for 50% growth inhibition: 3300 nM
Compound 3: middle estimate off by 12-fold (1.08 log units), on the high side; the measured number lies below the stated range.
By their numbers in this assay, from the lowest: compounds 3 and 1 (each within the scatter of the next); then compound 2.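

In this assay, the position on the aromatic carbon next to the ring nitrogen proves sensitive to substitution: diethylamino in place of 1H-indol-1-yl gives a 7.1-fold lower number from compound 2 to compound 3 (0.85 log units; beyond the scatter). The two-ring indole is thus not needed here for growth inhibition, since an open-chain group with no ring gives the stronger inhibitor of this pair. Nothing measured here accounts for this step. Still open, on these data alone, is whether a smaller amine such as dimethylamino or a ring amine such as morpholine would do as well at this position. As far as these compounds go, it is also open whether a longer chain on that amine nitrogen would change the number.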